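Amide variation on a methoxychromone acrylamide: notes toward compound 4

The compounds below may be only part of what the source reports. "The series", "measured", "known", "first", "only" and "open" are said of these compounds alone.

Measured so far in a functional assay on Huh-7 cells (Homo sapiens) for inhibition, read by MTT assay, with a stated time of 48 h; on this read-out lower numbers stand for stronger inhibition and higher numbers for weaker inhibition:
compound 1, `COc1ccc2c(=O)c(/C=C/C(=O)NCc3ccccc3)coc2c1`, 13600 nM
compound 2, `COc1ccc2c(=O)c(/C=C/C(=O)Nc3ccccc3)coc2c1`, 9050 nM
compound 3, `COc1ccc2c(=O)c(/C=C/C(=O)NCc3cccc(F)c3)coc2c1`, 10100 nM

The three compounds share one core and differ only in the group on the amide-type nitrogen. All three numbers sit close together: the step of a 1.5-fold lower number from compound 1 to compound 2 (0.18 log units; within the scatter) and the step of a 1.3-fold lower number from compound 1 to compound 3 (0.13 log units; within the scatter) both stay within the scatter, as does the step of a 1.1-fold higher number from compound 2 to compound 3 (0.05 log units; within the scatter). Compound 3 therefore stands apart from neither of the others; its number is not separable from that of compound 2, and only slightly further from compound 1.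

Compound 4, `COc1ccc2c(=O)c(/C=C/C(=O)Nc3ccccc3OC)coc2c1`, has not yet been measured. It differs from compound 3 as follows: 2-methoxyphenyl in place of 3-fluorobenzyl on an amide-type nitrogen. For the measured compounds named here, the steps that bear on this change are a 1.5-fold lower number from compound 1 to compound 2 (0.18 log units; within the scatter), a phenyl in place of a benzyl, and a 1.1-fold higher number from compound 2 to compound 3 (0.05 log units; within the scatter), both within the scatter. Going by the values given here, no measured compound carries a methoxy on the amide-side ring, so that part of the change has no precedent here. On the evidence of compound 2, the nearest measured relative, the expected step is a 1.1-fold lower number from compound 3 to compound 4 (0.03 log units; within the scatter) in this assay, none beyond the scatter. Compound 4 is estimated at 9500 nM, with a range from 4500 nM to 20000 nM.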

Compound 4, half-maximal inhibitory concentration: 32300 nM
For compound 4 the middle estimate is 3.4-fold (0.53 log units) below the measured one; measured number above the stated range.
By their numbers in this assay, from the lowest: compounds 2, 3 and 1 (each within the scatter of the next); then compound 4.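

In this assay, for the compounds shown here, the step of a 3.6-fold higher number from compound 2 to compound 4 (0.55 log units; beyond the scatter) comes from 2-methoxyphenyl taking the place of phenyl, and it is the first change to pass the scatter. The steps of a 3.2-fold higher number from compound 3 to compound 4 (0.50 log units; beyond the scatter) and a 2.4-fold higher number from compound 1 to compound 4 (0.38 log units; beyond the scatter) also pass it, so the 2-methoxyphenyl group stands apart from benzyl and 3-fluorobenzyl as well, while phenyl, benzyl and 3-fluorobenzyl remain inseparable. The group on the amide-type nitrogen therefore does matter, though the only separation seen so far runs toward weaker inhibition.

From the compounds shown here alone, whether an amine or a carboxylic acid in place of the methoxy would move the number the same way stays open. Nothing available gives a measured reason for this shift.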